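From trifluoromethyl to methylcarbamoyl on a long-lasting compound

The source may hold more compounds than are shown below. What is called first, only, known or untested is meant among the compounds shown, and "the series" means these compounds.

In an in vitro ADME assay on microsomes from liver (Homo sapiens) for metabolic stability, tested at 1 uM (a lower number here means that the compound disappears faster, a higher number that the compound lasts longer), compound 1 (`CS(=O)(=O)c1ccc(-c2cnc(N)c(-c3ccc(C(F)(F)F)c(F)c3)c2)cc1`) gives 2.05 h as its half-life. Compound 2 (`CS(=O)(=O)c1ccc(-c2cnc(N)c(-c3ccc(C(F)(F)F)cc3)c2)cc1`) gives > 4.16 h as its half-life, which is a limit of the assay and not a number. Compound 3 (`CNC(=O)c1ccc(-c2cc(-c3ccc(S(C)(=O)=O)cc3)cnc2N)cc1`) has methylcarbamoyl in place of trifluoromethyl on an aromatic carbon. Going by the values given here, the only measured step, an at least 2.0-fold higher number from compound 1 to compound 2 (0.30 log units; that floor lies within the scatter), exchanges fluoro for hydrogen and does not touch this group, so it offers only a rough guide to size. In this assay the expected move is an at least 1.3-fold lower number from compound 2 to compound 3 (0.14 log units; that floor lies within the scatter) and it points downward, though modestly. Compound 3 is estimated at 3 h as its half-life, with an expected range from 1.2 h to 6.5 h overall.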

Compound 3, half-life: > 5.83 h
Compound 3: a limit, no number; the forecaster's own chance of this, stated with the estimate: 35%; at least 1.9-fold (0.28 log units) between middle value and limit.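

Compound 2 and compound 3 both stand at limits of the assay, not numbers, and the step between them cannot be read. From the compounds shown here alone, whether methylcarbamoyl in place of trifluoromethyl changes the half-life, and in which direction, stays open.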